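Swapping One Benzyl Group on a Cytotoxic Compound

This account rests on a few compounds, and the source may have more. Where it says the series, first, only, none or still open, it means among the compounds named here.

Measured in a functional assay on DU-145 cells (Homo sapiens) for cytotoxicity, read by MTT assay, with a stated time of 24 h; on this read-out higher numbers stand for weaker inhibition and lower numbers for stronger inhibition:

- Compound 1 `COc1ccc(/C=C2\CN(Cc3cn(Cc4cccc(Cl)c4)nn3)C/C(=C\c3ccc(OC)cc3)C2=O)cc1` gives 15400 nM
- Compound 2 `Cc1ccc(/C=C2\CN(C(=S)SCc3cn(Cc4ccc(F)cc4)nn3)C/C(=C\c3ccc(C)cc3)C2=O)cc1` gives 38800 nM
- Compound 3 `COc1ccc(/C=C2\CN(C(=S)SCc3cn(Cc4cccc(Cl)c4)nn3)C/C(=C\c3ccc(OC)cc3)C2=O)cc1` gives > 80000 nM as a limit of the assay, not a number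

Of the two true numbers, compound 1 has the lower one, which on this read-out means stronger inhibition. The higher number of compound 2 lies beyond the usual scatter of repeated measurements. Compound 3 is reported only as a limit.

Still unmeasured is compound 4 `COc1ccc(/C=C2\CN(Cc3cn(Cc4ccc(F)cc4)nn3)C/C(=C\c3ccc(OC)cc3)C2=O)cc1` which keeps the core of compound 1 and alters one group: 4-fluorophenyl in place of 3-chlorophenyl on a saturated chain carbon bound to an aromatic nitrogen that is, 4-fluorophenyl in place of 3-chlorophenyl on a saturated chain carbon bound to an aromatic nitrogen, or 3-chlorobenzyl to 4-fluorobenzyl.

Among the compounds with values here, no two measured compounds differ in just one place, so this swap has no direct precedent here. Compound 2 also carries a 4-fluorobenzyl group, but it differs from compound 1 elsewhere too, so its value cannot single out this change. In this assay the expectation is therefore no step beyond the scatter in either direction, starting from compound 1 at 15400 nM as the closest measured relative. The estimated 1.2-fold higher number from compound 1 to compound 4 (0.07 log units; within the scatter) would fall within that scatter. Compound 4 is estimated to give 18000 nM in a range from 7000 nM to 45000 nM once it is measured.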

Compound 4, half-maximal inhibitory concentration: 59400 nM
Estimate against measurement, compound 4: 3.3-fold (0.52 log units) below, and the stated range ends below it.
By their numbers in this assay, from the lowest: compound 1; then compounds 2 and 4 (each within the scatter of the next). At a limit, above all of these: compound 3.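

In this assay, within the data shown here, the swap of 3-chlorobenzyl to 4-fluorobenzyl gives a 3.9-fold higher number from compound 1 to compound 4 (0.59 log units; beyond the scatter), a modest step, and it is the first change at a single place that can be read. It shows that the group on a saturated chain carbon bound to an aromatic nitrogen is not a neutral spectator for this read-out, even though 3-chlorophenyl and 4-fluorophenyl have the same count of heavy atoms and neither brings a hydrogen-bond donor or acceptor. Both the halogen and its location on the phenyl ring change in this one swap, so the step cannot be assigned to either alone, and nothing measured here explains it.

The compounds shown leave open how 4-chlorobenzyl or 3-fluorobenzyl would behave, the two groups that would pull the halogen and its location apart, and how plain benzyl, with no halogen at all, or a benzyl carrying an amine would compare. Also open, from the compounds shown here alone, is whether the same swap would have a similar effect on the longer linker carried by compound 2 and compound 3.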